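This account rests on a few compounds, and the source may have more. Where it says the series, first, only, none or still open, it means among the compounds named here.

Among the measured compounds shown here, in a functional assay on aorta for antagonist activity at Alpha-1D adrenergic receptor (Rattus norvegicus) (on this read-out higher numbers stand for weaker binding and lower numbers for tighter binding), compound 3 `COc1ccccc1N1CCN(CCCNc2ncccc2C(=O)N(C)C)CC1` gives 20 nM, the highest of the three numbers so far. Compound 1 `COc1ccccc1N1CCN(CCCNc2ncccc2C(=O)NC(C)(C)C)CC1` gives 10 nM, and the step of a 2.0-fold higher number from compound 1 to compound 3 (0.30 log units; within the scatter) stays within the scatter. Compound 2 `CNC(=O)c1cccnc1NCCCN1CCN(c2ccccc2OC)CC1` gives 3.16 nM; the step of a 6.3-fold higher number from compound 2 to compound 3 (0.80 log units; beyond the scatter) lies beyond it, as does a 3.2-fold lower number from compound 1 to compound 2 (0.50 log units; beyond the scatter). Compound 4 `CN(C)C(=O)c1cccnc1NCCCN1CCN(c2ccccc2OCC(F)(F)F)CC1` differs from compound 3 by trifluoromethyl in place of hydrogen on a saturated chain carbon bound to an oxygen on an aromatic ring. For the measured compounds named here, none of the measured steps touches this part of the molecule: all three change the amide-type nitrogen, so no measured step bears on the new change, and he expects no step beyond the scatter. His estimate for compound 4 is 20 nM, with a range from 6 nM to 63 nM, an expected step of no change at the digits printed from compound 3 to compound 4 (within the scatter).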

Compound 4, dissociation constant: 15.9 nM
Compound 4: middle estimate off by 1.3-fold (0.10 log units), on the high side; measured number inside the range.
By their numbers in this assay, from the lowest: compound 2; then compounds 1, 4 and 3 (each within the scatter of the next).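

In this assay, the change from methoxy to 2,2,2-trifluoroethoxy gives a 1.3-fold lower number from compound 3 to compound 4 (0.10 log units; within the scatter) and so stays within the scatter. Among the compounds shown here, this shows that the position on the saturated chain carbon bound to an oxygen on an aromatic ring, which the earlier steps at the amide-type nitrogen left untouched, accepts trifluoromethyl in place of hydrogen without a step beyond the scatter. Nothing available explains this result.
Going by these compounds, it remains open whether an amine, a carboxylic acid or a longer chain at this position would also stay within the scatter. On these data alone, whether trifluoromethyl does the same on compound 2 also remains open.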